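This account rests on a few compounds, and the source may have more. Where it says the series, first, only, none or still open, it means among the compounds named here.

Measured so far in an assay for inhibition of Polyunsaturated fatty acid 5-lipoxygenase (Homo sapiens), read by spectrophotometry, tested at 10 uM; a higher number here means more inhibition at the concentration tested (going by the name of the read-out), a lower number less inhibition:
compound 1 `O=C(c1ccccc1)c1sc(N2CCN(c3ccccc3)CC2)nc1-c1ccccc1` gives 38.3%
compound 2 `COc1ccc(-c2nc(N3CCN(c4ccccc4)CC3)sc2C(=O)c2ccccc2)cc1` gives 53.1%
compound 3 `O=C(NC(=S)N(c1ccccc1)c1ccccc1)c1ccccc1` gives 73.3%

One change is measured once: methoxy in place of hydrogen on an aromatic carbon, and it gives the step of a number 14.8 percentage points higher from compound 1 to compound 2 (beyond the scatter). Compound 3 stands highest of the three measured numbers; the difference between its core and the core of compound 1 is not broken down here.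

Compound 4 `COc1ccc(C(=O)NC(=S)N(c2ccccc2)c2ccccc2)cc1` is not yet measured. It carries the same change on the core of compound 3: methoxy in place of hydrogen on an aromatic carbon. The place of the change is described in the same words in both pairs.

Among the measured compounds shown here, the step from compound 3 to compound 4 is expected to run in the same direction, since a number 14.8 percentage points higher from compound 1 to compound 2 (beyond the scatter) is the single precedent for this change; an estimated a number 7.7 percentage points higher from compound 3 to compound 4 (within the scatter) is taken, held smaller because compound 3 already gives 73.3%, leaving less room for a rise. Compound 4 is therefore expected near 81%, within 64% to 93%.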

Compound 4, a percentage reported as inhibition, at one concentration (the size of the read-out at that concentration, not a potency): 19.2%
Compound 4: middle estimate off by 61.8 percentage points, on the high side, and the stated range ends above it.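

In this assay, methoxy in place of hydrogen on an aromatic carbon gives a number 54.1 percentage points lower from compound 3 to compound 4 (beyond the scatter), and the earlier step on the other core runs the opposite way: the same change on two cores in this assay, a number 14.8 percentage points higher (beyond the scatter) from compound 1 to compound 2 and a number 54.1 percentage points lower (beyond the scatter) from compound 3 to compound 4, 68.9 percentage points apart, beyond the scatter of two such steps. This change therefore does not carry between the core of compound 1 and the core of compound 3, and a step on one core predicts neither the direction nor the size of the step on the other. With one pair per core, the data do not show which part of either core sets the difference, or how any other change would carry.

On these data alone, it remains open whether the drop on the core of compound 3 belongs to methoxy alone or to any group at that place, where only hydrogen and methoxy appear. A hydroxyl, an amine or a longer chain such as ethoxy at that place would bear on this.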